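This account rests on a few compounds, and the source may have more. Where it says the series, first, only, none or still open, it means among the compounds named here.

Two nucleoside-like compounds sharing one core have been tested in a functional assay on A549 cells (Homo sapiens), read by MTT assay, with a stated time of 72 h; on this read-out higher numbers stand for weaker inhibition and lower numbers for stronger inhibition. Compound 1, `COc1ncnc2c1c(-c1ccsc1)cn2[C@@H]1O[C@H](CO)[C@@H](O)[C@H]1O`, carries a thiophen-3-yl group and a methoxy group, and in this assay compound 1 gives 5170 nM. Compound 2, `Cc1ncnc2c1c(-c1cc3ccccc3o1)cn2[C@@H]1O[C@H](CO)[C@@H](O)[C@H]1O`, carries a 1-benzofuran-2-yl group and a methyl group instead. For compound 2 the assay returns only a limit, > 20000 nM, so its true value is not known as a number; this limit is the limit of > 20000 nM in this assay, at which 1 of the 2 values shown sits. Compound 3, `Cc1ncnc2c1c(-c1ccsc1)cn2[C@@H]1O[C@H](CO)[C@@H](O)[C@H]1O`, keeps the methyl group of compound 2 but changes the aromatic substituent: thiophen-3-yl in place of 1-benzofuran-2-yl on an aromatic carbon. Since compound 1, which also bears thiophen-3-yl, gives a measurable value, the step is expected to bring the read-out from the limit into the measurable range, the expected step being an at least 2.2-fold lower number from compound 2 to compound 3 (0.34 log units; beyond the scatter). Compound 3 is estimated to give 9000 nM, expected to lie between 2500 nM and 30000 nM.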

Compound 3, half-maximal inhibitory concentration: > 20000 nM
Compound 3: a limit, no number; the forecaster's own chance of this, stated with the estimate: 35%; middle value at least 2.2-fold (0.34 log units) from the limit.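

Both compound 2 and compound 3 end at a limit, not a number, so the step between them cannot be read, and placing thiophen-3-yl in place of 1-benzofuran-2-yl on this aromatic carbon does not lift the read-out into the measurable range: the limit of > 20000 nM in this assay, at which 2 of the 3 values shown sit.

With thiophen-3-yl held the same, the change of methyl in place of methoxy on an aromatic carbon gives in this assay an at least 3.8-fold higher number from compound 1 to compound 3 (0.58 log units; beyond the scatter). Among the compounds shown, thiophen-3-yl alone therefore does not secure a measurable value, and the only one with a number, compound 1, carries it together with methoxy.

Going by these compounds, how 1-benzofuran-2-yl behaves alongside methoxy remains open. So does whether an amine or a longer chain such as ethoxy, in place of methoxy, would keep a measurable value.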